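The compounds below may be only part of what the source reports. "The series", "measured", "known", "first", "only" and "open" are said of these compounds alone.

Values measured in a functional assay on QGY cells (Homo sapiens) for cytotoxicity, read by MTT assay, with a stated time of 48 h; on this read-out higher numbers stand for weaker inhibition and lower numbers for stronger inhibition:
- compound 1 `CCOC(=O)[C@@]1(C(=O)Nc2ccccc2Cl)C[C@@H]1c1cc(OC)c(OC)c(OC)c1`: > 100000 nM
- compound 2 `CCOC(=O)[C@@]1(C(=O)NCc2ccc(C)cc2)C[C@H]1c1cc(OC)c(OC)c(OC)c1`: 26400 nM
- compound 3 `COc1cc([C@@H]2C[C@@]2(CO)C(=O)NCc2ccc(C)cc2)cc(OC)c1OC`: 58700 nM

The entry for compound 1 is a limit of the assay and not a number. Of the two true numbers, compound 2 has the lower, 26400 nM. Among the compounds with values here, the only measured step is a 2.2-fold higher number from compound 2 to compound 3 (0.35 log units; beyond the scatter), and it bears on the question only loosely, since it puts hydroxymethyl in place of ethoxycarbonyl and does not alter a configuration.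

Compound 4 `CCOC(=O)[C@@]1(C(=O)NCc2ccc(C)cc2)C[C@@H]1c1cc(OC)c(OC)c(OC)c1` is the next to be measured in this assay. The structural change is the two compounds have the same atoms and bonds and differ only in configuration as drawn: 1 of 2 stereo elements differ; a stereocentre at a saturated ring carbon is drawn S in compound 2 and R in compound 4. Within the data shown here, no measured step tests a change of this kind, so its size is uncertain: it could stay within the scatter or be large. Compound 2 already has the lowest number at 26400 nM, so a rise is more likely than a fall. The expected change is a 1.7-fold higher number from compound 2 to compound 4 (0.23 log units; within the scatter). For compound 4 the estimated value is 45000 nM, with an expected range of 15000 nM to 100000 nM.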

Compound 4, half-maximal inhibitory concentration: > 100000 nM
Compound 4 was reported as a limit (the forecaster's own chance of this, stated with the estimate: 25%); middle value at least 2.2-fold (0.34 log units) away from the limit.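

In this assay, a change at one stereocentre on a saturated ring carbon, from S to R as drawn, gives an at least 3.7-fold higher number from compound 2 to compound 4 (0.57 log units; beyond the scatter), so at this position the configuration alone can shift the read-out beyond the scatter, which compounds 2 and 3 could not show. The entry for compound 4, > 100000 nM, is a limit of the assay and not a number, and the shift can be tied to configuration because nothing else changes: the fact that compounds 2 and 4 differ only in the configuration as drawn The step between compound 1 and compound 4 cannot be read, as both entries are the same limit: the limit of > 100000 nM in this assay, at which 2 of the 4 values shown sit.

From the compounds shown here alone, what the second stereo element contributes stays open. So does whether this change of configuration would have a similar effect with hydroxymethyl, a carboxylic acid or an aminomethyl group in place of ethoxycarbonyl.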